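From compound 1 to compound 4: one ring group exchanged

This account rests on a few compounds, and the source may have more. Where it says the series, first, only, none or still open, it means among the compounds named here.

Compound 1 `N#Cc1ccc(OCCCCCn2cc(/C=C3\NC(=O)NC3=O)c3ccccc32)cc1` gives 33 ug/mL as a number
Compound 2 `O=C1NC(=S)N/C1=C\c1cn(CCCCCN2CCN(c3ccccc3)CC2)c2ccccc12` gives > 100 ug/mL as a limit
Compound 3 `N#Cc1ccc(OCCCCn2cc(/C=C3\NC(=S)NC3=O)c3ccccc32)cc1` gives > 100 ug/mL as a limit

For the measured compounds named here, in an ADME assay on J774.A1 cells (Mus musculus) for cytotoxicity, read by MTT assay (on this read-out lower numbers stand for stronger inhibition and higher numbers for weaker inhibition), compound 1 gives 33 ug/mL as the only true number in the set. The other two results are limits of the assay and not numbers, as this summary shows: the limit of > 100 ug/mL in this assay, at which 2 of the 3 values shown sit. Compound 4 `CSC1=N/C(=C\c2cn(CCCCCOc3ccc(C#N)cc3)c3ccccc23)C(=O)N1` has not yet been measured. It differs from compound 1 at one place a group of 9 heavy atoms (5 carbon, 2 nitrogen, 1 oxygen, 1 sulfur; one five-membered non-aromatic ring with 2 hetero atoms) in place of a group of 8 heavy atoms (4 carbon, 2 nitrogen, 2 oxygen; one five-membered non-aromatic ring with 2 hetero atoms), on an aromatic carbon and keeps the rest of the structure. Going by the values given here, no measured pair of compounds isolates this exchange, so compound 1 at 33 ug/mL remains the only numerical anchor. Compounds 2 and 3 differ from compound 1 in more than this one place, so they cannot size the step. The expectation in this assay is therefore no change beyond the usual scatter and no firm direction, although a result reported only as a limit remains possible. The estimated change is a 1.2-fold higher number from compound 1 to compound 4 (0.08 log units; within the scatter) and it is expected to be small. Compound 4 is expected at 40 ug/mL with 14 ug/mL to 100 ug/mL as its estimated range.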

Compound 4, half-maximal inhibitory concentration: > 100 ug/mL
Compound 4 was reported as a limit; the forecaster's own chance of this, stated with the estimate: 25%; middle value at least 2.5-fold (0.39 log units) from the limit.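

In this assay, for the compounds shown here, this is the first single exchange that can be read on the aromatic carbon two ring bonds from the ring nitrogen, and it gives an at least 3.0-fold higher number from compound 1 to compound 4 (0.48 log units; beyond the scatter). The ring group at this place therefore matters to the read-out: the entering group, with 1 hydrogen-bond donor and 3 hydrogen-bond acceptors, moves the result towards weaker inhibition than the leaving group, with 2 of each. The result for compound 4 is a limit of the assay and not a number, so the step has a smallest possible size but no measured one: the limit of > 100 ug/mL in this assay, at which 3 of the 4 values shown sit.

The compounds shown do not separate the part played by the sulfur atom from that of the extra carbon in the entering group. On these data alone, whether a ring group carrying an amine or a carboxylic acid at this place would give a true number also stays open.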